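This account rests on a few compounds, and the source may have more. Where it says the series, first, only, none or still open, it means among the compounds named here.

Compound 1, `CCc1ccc2oc(CSc3nnc(CNc4ccccc4)n3CC)nc2c1`: "not determined" (no result reported)
Compound 2, `CCC(=O)c1ccc2oc(CS(=O)(=O)c3nnc(CNc4ccccc4)n3CC)nc2c1`: 44%

In an ADME assay on blood (Rattus norvegicus) for metabolic stability, with a stated time of 2 h (a lower number here means that less of the compound is left, a higher number that more of the compound is left), compound 1 gives "not determined" (no result reported), so it offers no number to start from. Compound 3, `CCn1c(CNc2ccccc2)nnc1SCc1nc2cc(C(=O)C(C)C)ccc2o1`, differs from compound 1 in one place: isopropylcarbonyl in place of ethyl on an aromatic carbon. This puts isopropylcarbonyl in place of ethyl on an aromatic carbon. Within the data shown here, no measured pair shows what such a change does, so the size and direction of this step cannot be read from the data. Among the measured compounds shown here, the only guide is compound 2, which gives 44% and also carries a carbonyl. A result for compound 3 within the scatter of that value is therefore expected, with no clear direction. For compound 3 the estimated value is 55%, with an expected range from 25% to 85%.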

Compound 3, percent of the compound remaining: 42%
Estimate against measurement, compound 3: 13 percentage points above; the measured number falls inside the stated range.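

No step can be read from compound 1 to compound 3: in this assay compound 1 gives "not determined" (no result reported) and compound 3 gives 42%. What isopropylcarbonyl in place of ethyl does to this result stays open, and nothing measured here offers an explanation.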